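Exchanging the Ortho-Methylphenyl for Difluorophenyl on a Pyrrole

A few compounds are considered here, and "the series" means these few. Any claim that something is new, unique, unknown or untested is made for them only; others in the source may bear on it.

Measured so far:
Compound 1, `COc1cc(C(=O)c2cn(-c3ccccc3Cl)cc2-c2ccccc2)cc(OC)c1OC`, gives 1800 nM.
Compound 2, `COc1cc(C(=O)c2cn(-c3ccccc3)cc2-c2ccccc2C)cc(OC)c1OC`, gives 190 nM.

The two compounds were tested in a functional assay on MCF7 cells (Homo sapiens) for cytotoxicity, read by MTT assay, with a stated time of 96 h; a higher number here means a weaker inhibitor, a lower number a stronger inhibitor. Compound 2 has the lower of the two numbers; compound 1 sits well above it, and the gap between the two values is beyond the usual scatter of this kind of measurement. The two differ in more than one place, so their values are reported here only as they stand, without a step between them.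

Compound 3, `COc1cc(C(=O)c2cn(-c3ccccc3)cc2-c2cc(F)ccc2F)cc(OC)c1OC`, has not yet been measured in this assay. It is derived from compound 2 by the change (2,5-difluorophenyl in place of 2-methylphenyl on an aromatic carbon). Among the compounds with values here, whether a 2,5-difluorophenyl serves as well as a 2-methylphenyl at that aromatic carbon cannot be read from the two values shown; no measured pair isolates this change. The account therefore treats compound 3 with caution. Compound 3 is expected to give about 400 nM in this assay, with a plausible range from 100 nM to 1600 nM. The step from compound 2 to compound 3 is expected to be a 2.1-fold higher number from compound 2 to compound 3 (0.32 log units; beyond the scatter), a modest weakening that may not exceed the scatter.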

Compound 3, half-maximal inhibitory concentration: 230 nM
Estimate against measurement, compound 3: 1.7-fold (0.24 log units) above, within the range that was stated.
By their numbers in this assay, from the lowest: compounds 2 and 3 (each within the scatter of the next); then compound 1.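

In this assay the exchange of 2-methylphenyl for 2,5-difluorophenyl, on an aromatic carbon of the five-membered aromatic ring with 1 nitrogen, comes out as a 1.2-fold higher number from compound 2 to compound 3 (0.08 log units; within the scatter) and so does not separate the two groups at this position. Within the data shown here, this is the first pair in the set that differs in one place, and it shows that, for these two compounds, the methyl group is not needed for a value in this range, since a phenyl ring bearing two fluorine atoms and no methyl group serves as well on the shared core. The pair comes with no accompanying measurement that could account for this result, so its basis remains unexplained.

Going by these compounds, the pair covers only a 2-methylphenyl and a 2,5-difluorophenyl at this position, so it remains open whether the same holds when the ring at that carbon carries an amine or a carboxylic acid. It also leaves open whether a single fluorine atom, or either of the two fluorine atoms taken alone, would give a value like those of compound 2 and compound 3.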